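The compounds below may be only part of what the source reports. "The series", "measured", "known", "first", "only" and "open" are said of these compounds alone.

Of the compounds shown here, two have so far been tested in a toxicity assay on THP-1 cells (Homo sapiens) for inhibition; on this read-out higher numbers stand for lower toxicity in this test and lower numbers for higher toxicity in this test. Compound 1 `Cn1c(-c2ccccc2Cl)cnc1NC(=O)c1ccc(F)cc1` gives only a limit of the test, > 50000 nM. Compound 2 `COc1ccc(-c2cnc(NC(=O)c3ccco3)n2C)cc1` likewise gives only a limit, > 100000 nM. Both results therefore sit at limits, one at the limit of > 100000 nM in this assay, at which 1 of the 2 values shown sits, and one at the limit of > 50000 nM in this assay, at which 1 of the 2 values shown sits, so no true number is known for either compound, and the whole range in which compound 2 stands is a limit. For the measured compounds named here, no step between measured compounds that differ in a single place is available. The change from compound 2 to compound 3 `COc1ccc(-c2cnc(NC(=O)c3ccn[nH]3)n2C)cc1` is 1H-pyrazol-5-yl in place of furan-2-yl on a carbonyl carbon. Nothing measured shows what this change does in this assay, so the expected step is a number no higher from compound 2 to compound 3 (the limit leaves the size open), that is no change beyond the scatter, with compound 3 most likely again reaching only a limit. Compound 3 is therefore estimated at 100000 nM, within the range 40000 nM to 250000 nM.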

Compound 3, half-maximal cytotoxic concentration: > 100000 nM
Compound 3 ended at the assay's limit; the forecaster's own chance of this, stated with the estimate: 80%; the middle value lies on the limit itself.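

Compound 2 and compound 3 both end at a limit in this assay, so no step can be read between them. The compounds shown leave open what true values lie behind these limits, and whether 1H-pyrazol-5-yl in place of furan-2-yl changes the result at all.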